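Isomeric pyridyl thiophene sulfonamides in the factor X series

The source may report more compounds than this note shows. Statements on the series, on what has been measured and on what is new or still open speak of the compounds shown alone.

Measured compounds:
Compound 1 `O=C1[C@@H](NS(=O)(=O)c2ccc(-c3ccon3)s2)CCN1Cc1cc2c[nH]ccc-2n1` — 17%
Compound 2 `O=C1[C@@H](NS(=O)(=O)c2ccc(-c3ccncc3)s2)CCN1Cc1cc2[nH]cccc-2n1` — 35%
Compound 3 `O=C1[C@@H](NS(=O)(=O)c2ccc(-c3ccccn3)s2)CCN1Cc1cc2c[nH]ccc-2n1` — 11%

In an assay on isolated protein for inhibition of coagulation factor X (Oryctolagus cuniculus), tested at 1 uM (on this read-out lower numbers stand for less inhibition and higher numbers for more inhibition at the one concentration tested (going by the name of the read-out)), compound 3 gives 11% and thereby stands lowest of the three numbers. Its nearest neighbour is compound 1, which gives 17%; the step of a number 6 percentage points lower from compound 1 to compound 3 (within the scatter) is within the scatter, so no order between these two can be stated. Compound 2 gives 35%, and that value lies beyond the scatter above compound 3; compound 2 differs from compound 3 both in the aryl group on the thiophene and in the shared core, so the gap cannot be assigned to one change.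

Compound 4 `O=C1[C@@H](NS(=O)(=O)c2ccc(-c3ccncc3)s2)CCN1Cc1cc2c[nH]ccc-2n1` is the next compound in this assay. Relative to compound 3 it carries pyridin-4-yl in place of pyridin-2-yl on an aromatic carbon. For the measured compounds named here, no measured step isolates this change on the core of compound 3. Going by the values given here, the one measured step touching the aryl group, a number 6 percentage points lower from compound 1 to compound 3 (within the scatter), was within the scatter. Among the compounds with values here, compound 2 is the only measured compound bearing pyridin-4-yl, and it gives the highest number, but on a different core.

The expectation for compound 4 is therefore a moderate rise, a number 11 percentage points higher from compound 3 to compound 4 (beyond the scatter), with an estimated value of 22% and a range from 5% to 42%.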

Compound 4, a percentage reported as inhibition, at one concentration (the size of the read-out at that concentration, not a potency): 21%
Compound 4: the middle estimate sits 1 percentage points above what was measured; low and high end bracket the measured number.
By their numbers in this assay, from the lowest: compounds 3, 1 and 4 (each within the scatter of the next); then compound 2.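

In this assay pyridin-4-yl in place of pyridin-2-yl, on the aromatic carbon next to the ring sulfur, gives a number 10 percentage points higher from compound 3 to compound 4 (within the scatter) and pyridin-4-yl in place of 1,2-oxazol-3-yl gives a number 4 percentage points higher from compound 1 to compound 4 (within the scatter) so the three aryl groups cannot be put in any order at this position on the shared core. For the compounds shown here, with pyridin-4-yl held constant, the exchange of the two isomeric groups on the saturated chain carbon bound to the amide-type nitrogen gives a number 14 percentage points lower from compound 2 to compound 4 (beyond the scatter) and this modest step is the only single-place change in the set that lies beyond the scatter, which points to that part of the molecule rather than the aryl position as the place where the read-out moves. Nothing on hand accounts for either finding.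

Going by these compounds, how pyridin-2-yl and 1,2-oxazol-3-yl behave on the core of compound 2 remains open, as does whether that core's advantage holds with other aryl groups. Also open, on these data alone, is the read-out at the aryl position with a non-aromatic group such as an aminomethyl group or a carboxylic acid, and all these numbers remain single-concentration readings rather than potencies.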